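Chloro to tert-butyl on a urea-linked quinoline series

The source may hold more compounds than are shown below. What is called first, only, known or untested is meant among the compounds shown, and "the series" means these compounds.

Compound 1, `Cc1cc(NC(=O)Nc2ccc(C(C)(C)C)cc2)c2ccccc2n1`, in an ADME assay on Raji cells (Homo sapiens) for cytotoxicity, with a stated time of 72 h (on this read-out lower numbers stand for an effect already at smaller amounts and higher numbers for an effect only at larger amounts of compound), gives > 25000 nM, which is a limit of the assay.
Compound 2, `Cc1cc(NC(=O)Nc2ccc(Cl)cc2)c2ccccc2n1`, in this assay gives > 25000 nM, again a limit.
Compound 3, `Cc1cc(NC(=O)Nc2cccc(Cl)c2)c2ccccc2n1`, in this assay gives 18000 nM.

The change tert-butyl in place of chloro on an aromatic carbon gave a step that the two limits leave unreadable from compound 2 to compound 1, because of the limit of > 25000 nM in this assay, at which 2 of the 3 values shown sit. The two cores differ by 3-chlorophenyl in place of 4-chlorophenyl on an amide-type nitrogen, a change that gave an at least 1.3-fold lower number from compound 2 to compound 3 (0.14 log units; that floor lies within the scatter). Compound 4, `Cc1cc(NC(=O)Nc2cccc(C(C)(C)C)c2)c2ccccc2n1`, is not yet measured; it carries tert-butyl in place of chloro on an aromatic carbon, the same kind of change as in compound 1, though there the group sits para to a large group and here meta to a large group. Set beside a step that the two limits leave unreadable from compound 2 to compound 1, the expected step is a 1.4-fold higher number from compound 3 to compound 4 (0.14 log units; within the scatter), resting on compound 3 at 18000 nM and on the unreadable step, because of the limit of > 25000 nM in this assay, at which 2 of the 3 values shown sit. Compound 4 is expected near 25000 nM.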

Compound 4, half-maximal effective concentration: > 25000 nM
Compound 4: a limit, no number; the forecaster's own chance of this, stated with the estimate: 55%; the middle value lies on the limit itself.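

In this assay, tert-butyl in place of chloro on an aromatic carbon gave an at least 1.3-fold higher number from compound 3 to compound 4 (0.14 log units; that floor lies within the scatter). Compound 4 gives > 25000 nM, which is a limit of the assay and not a number. The same change from compound 2 to compound 1 cannot be read, so nothing shows whether the step carries over from one core to the other, because the values sit at a limit: the limit of > 25000 nM in this assay, at which 3 of the 4 values shown sit.

The compounds shown leave open what an amine or a carboxylic acid would give in place of the chloro or tert-butyl group. They also leave open whether a smaller group, such as methyl or methoxy, would give a value that can be read as a number on either core.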